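An Aryl Cap on the Piperazine of Compound 3

The source may hold more compounds than are shown below. What is called first, only, known or untested is meant among the compounds shown, and "the series" means these compounds.

Compound 3 `COc1ccc(S(=O)(=O)N2CC(C(=O)N3CCNCC3)c3ccccc32)c2ccccc12` gives 7.94 nM in a functional assay on CHO cells for antagonist activity at 5-hydroxytryptamine receptor 6 (Homo sapiens), read by FLIPR; on this read-out higher numbers stand for weaker inhibition and lower numbers for stronger inhibition. It stands level with compound 1 `COc1ccc(S(=O)(=O)N2CC(C(=O)N(C)C3CCN(C)CC3)c3ccccc32)c2ccccc12`, which gives 7.94 nM, and together these two hold the lowest numbers of the three. Compound 2 `COc1ccc(S(=O)(=O)N2CC(C(=O)NC3CCN(C)CC3)c3ccccc32)c2ccccc12` gives 25.1 nM; the step of a 3.2-fold lower number from compound 2 to compound 3 (0.50 log units; beyond the scatter) is modest but beyond the scatter, whereas no change at the digits printed from compound 1 to compound 3 (within the scatter) falls within it.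

Compound 4 `COc1cccc(N2CCN(C(=O)C3CN(S(=O)(=O)c4ccc(OC)c5ccccc45)c4ccccc43)CC2)c1` differs from compound 3 by 3-methoxyphenyl in place of hydrogen on an amine nitrogen in a ring. Within the data shown here, no measured step touches this ring nitrogen. The nearest comparison is a 3.2-fold higher number from compound 1 to compound 2 (0.50 log units; beyond the scatter), a modest change at a different nitrogen, and the other two steps exchange the whole amine-bearing group and end either within the scatter or at the same modest size. Placing an aromatic group on the ring nitrogen of compound 3 is a larger alteration than any of these, so the data give no direct guide; a modest rise of the number, expected as a 3.8-fold higher number from compound 3 to compound 4 (0.58 log units; beyond the scatter), is the cautious reading, with the range held wide to cover either direction. Compound 4 is therefore expected to give 30 nM, between 6 nM and 150 nM.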

Compound 4, inhibition constant: 63.1 nM
The estimate for compound 4 lay 2.1-fold (0.32 log units) below the measured number; low and high end bracket the measured number.
By their numbers in this assay, from the lowest: compounds 1 and 3 (each within the scatter of the next); then compound 2; then compound 4.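

In this assay, the ring nitrogen of the piperazine now has a measured step of its own: a 7.9-fold higher number from compound 3 to compound 4 (0.90 log units; beyond the scatter) for 3-methoxyphenyl in place of hydrogen. This is larger than either step seen earlier among the compounds on the amide side, a 3.2-fold higher number from compound 1 to compound 2 (0.50 log units; beyond the scatter) at the amide-type nitrogen and a 3.2-fold lower number from compound 2 to compound 3 (0.50 log units; beyond the scatter) on exchange of the amine-bearing group, so the change at this ring nitrogen moves the number further than any change shown before, though it is still graded modest and compound 4 still gives a measured 63.1 nM here. Nothing shown bears on why the number rises when this group enters at this position.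

The compounds shown leave open how a plain phenyl, a methyl or a benzyl on this ring nitrogen would read, and so whether the rise follows the aromatic ring itself or the methoxy it carries. With one group on this nitrogen there is a single point here and not yet a trend.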